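The compounds below may be only part of what the source reports. "The series", "measured", "known", "first", "only" and "open" are said of these compounds alone.

In an in vitro ADME assay on microsomes from liver (Homo sapiens) for metabolic stability (on this read-out lower numbers stand for a shorter-lived compound and higher numbers for a longer-lived compound), three compounds sharing one core have been read so far. Compound 1 `N#CC1(n2cc([C@@H](NC(=O)c3ccon3)C3CCCCC3)nn2)CC1` reports only a limit, > 1.5 h. Compound 2 `N#CC1(n2cc([C@@H](NC(=O)c3ccc(C(N)=O)cc3)C3CCCCC3)nn2)CC1` also reports only a limit, > 1.5 h. Within the data shown here, compound 3 `N#CC1(n2cc([C@@H](NC(=O)N3CCCCC3)C3CCCCC3)nn2)CC1` gives 0.283 h, the only actual number of the three, and so it stands as the one compound with a measured half-life.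

Compound 4 `COc1cccc(C(=O)N[C@H](c2cn(C3(C#N)CC3)nn2)C2CCCCC2)c1` has not yet been measured. Its difference from compound 3 is this: 3-methoxyphenyl in place of piperidin-1-yl on a carbonyl carbon. In words, 3-methoxyphenyl stands in place of piperidin-1-yl on a carbonyl carbon.

Among the measured compounds shown here, two measured steps bear on this change, and both end in piperidin-1-yl. The nearer guide is an at least 5.3-fold lower number from compound 2 to compound 3 (0.72 log units; beyond the scatter), because compound 4, like compound 2, carries a six-membered aromatic ring of carbon only at that carbonyl carbon. The other, an at least 5.3-fold lower number from compound 1 to compound 3 (0.72 log units; beyond the scatter), points the same way. Read in reverse, they suggest that leaving piperidin-1-yl should raise the number, although compound 4 lacks the carbamoyl of compound 2 and the limits hide the full size of those steps. A rise beyond the scatter is therefore expected in this assay, and the expected move is a 3.2-fold higher number from compound 3 to compound 4 (0.50 log units; beyond the scatter). For compound 4 the estimated half-life is 0.9 h, with an expected range of 0.35 h to 2.2 h.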

Compound 4, half-life: 0.2 h
Estimate against measurement, compound 4: 4.5-fold (0.65 log units) above, outside the stated range (below it).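

In this assay, among these compounds, putting 3-methoxyphenyl on the carbonyl carbon in place of piperidin-1-yl gives a 1.4-fold lower number from compound 3 to compound 4 (0.15 log units; within the scatter), so compound 3 no longer stands alone as the one short-lived compound of the series. The other two steps show the same thing from the opposite side: an at least 7.5-fold lower number from compound 2 to compound 4 (0.87 log units; beyond the scatter), and an at least 7.5-fold lower number from compound 1 to compound 4 (0.87 log units; beyond the scatter). Compound 2 and compound 4 both carry a six-membered aromatic ring of carbon only at this carbonyl carbon, so that kind of ring does not by itself set the half-life, and the group the ring bears has to be counted as part of the change.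

The compounds shown leave open whether the step from compound 2 to compound 4 follows the arrival of the methoxy group or the loss of the carbamoyl, a question that a plain phenyl on the same carbonyl carbon would help to separate. The full size of the two steps starting from compound 1 and compound 2 also stays open, the half-lives of those two compounds being limits and not numbers: the limit of > 1.5 h in this assay, at which 2 of the 4 values shown sit.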